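Two Methyl Extensions and a Cytotoxicity Ceiling

This account rests on a few compounds, and the source may have more. Where it says the series, first, only, none or still open, it means among the compounds named here.

Among the compounds with values here, compound 1 `CCc1cccc2c(OC)c(-c3occ(C)c3CO)ccc12` is the only member of this small set with a numerical reading: in a functional assay on DU-145 cells (Homo sapiens) for cytotoxicity, read by MTT assay, with a stated time of 72 h (on this read-out lower numbers stand for an effect already at smaller amounts and higher numbers for an effect only at larger amounts of compound), compound 1 gives 7.2 ug/mL. Compound 2 `CCOc1c(-c2occ(C)c2CO)ccc2c(CC)cccc12` carries methyl in place of hydrogen on a saturated chain carbon bound to an oxygen on an aromatic ring. In this assay compound 2 reaches only the limit > 10 ug/mL. That change made an at least 1.3-fold higher number from compound 1 to compound 2 (0.14 log units; that floor lies within the scatter). Compound 3 `CCc1cccc2c(OC)c(-c3occ(C)c3COC)ccc12` differs from compound 1 by methyl in place of hydrogen on an oxygen on a saturated carbon. In this assay compound 3 likewise stops at the limit > 10 ug/mL. Compound 4 `CCOCc1c(C)coc1-c1ccc2c(CC)cccc2c1OC` differs from compound 3 by methyl in place of hydrogen on a saturated chain carbon bound to an oxygen on a saturated carbon. This is the same kind of change as from compound 1 to compound 2, though here the oxygen sits on a saturated carbon rather than on an aromatic ring. Because compound 3 sits at the limit of > 10 ug/mL in this assay, at which 2 of the 3 values shown sit, and because the earlier step was an at least 1.3-fold higher number from compound 1 to compound 2 (0.14 log units; that floor lies within the scatter), compound 4 is expected to remain at the limit, the expected step being a step that the limit leaves unreadable from compound 3 to compound 4. The estimated value for compound 4 is 15 ug/mL, between 8 ug/mL and 40 ug/mL.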

Compound 4, concentration for half-maximal effect: > 10 ug/mL
Compound 4 ended at the assay's limit (the forecaster's own chance of this, stated with the estimate: 80%); the middle value lies beyond the limit too.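

In this assay compound 4 stands at > 10 ug/mL and that is a limit of the assay, not a number. Within the data shown here, the one readable step is an at least 1.3-fold higher number from compound 1 to compound 4 (0.14 log units; that floor lies within the scatter), so it establishes no real change. The methyl extension therefore cannot be said to carry over, or to fail to carry over, from the methoxy to ethoxy change to the methoxymethyl to ethoxymethyl change, and the unreadable steps give no size to compare: the limit of > 10 ug/mL in this assay, at which 3 of the 4 values shown sit.

The compounds shown leave open whether an amine or a carboxylic acid in place of the ethoxymethyl group would give a reading on this scale. They also leave open how a longer chain on that oxygen would read.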